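The source may hold more compounds than are shown below. What is called first, only, known or untested is meant among the compounds shown, and "the series" means these compounds.

Measured in a functional assay on MDA-MB-231 cells (Homo sapiens) for antiproliferative activity, read by MTT assay, with a stated time of 48 h; a lower number here means a stronger inhibitor, a higher number a weaker inhibitor:

- Compound 1 `COc1ccc(N(C)c2ccnc(Cl)n2)cc1F`: 1280 nM
- Compound 2 `COc1ccc(N(C)c2ccnc(Cl)n2)cc1[N+](=O)[O-]`: 8120 nM

Compound 2, at 8120 nM, has the higher of the two numbers, which makes it the weaker inhibitor of this pair. The next compound, compound 3 `COc1ccc(N(C)c2ccnc(Cl)n2)cc1OCCCBr`, carries 3-bromopropoxy in place of nitro on an aromatic carbon, ortho to a methoxy group: 3-bromopropoxy in place of nitro on an aromatic carbon.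

Going by the values given here, only one measured step bears on this change: a 6.3-fold higher number from compound 1 to compound 2 (0.80 log units; beyond the scatter). This modest step also replaced a group at the same aromatic carbon, and it shows nitro giving the higher number. Among the compounds with values here, no measured compound carries 3-bromopropoxy, so the evidence is thin. A modest step towards a lower number is expected, with real uncertainty in its size and direction. The expected change is a 2.7-fold lower number from compound 2 to compound 3 (0.43 log units; beyond the scatter). For compound 3 the estimated value is 3000 nM, with an expected range of 700 nM to 12000 nM.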

Compound 3, half-maximal inhibitory concentration: 1280 nM
The estimate for compound 3 lay 2.3-fold (0.37 log units) above the measured number; the measured number falls inside the stated range.
By their numbers in this assay, from the lowest: compounds 1 and 3 (each within the scatter of the next); then compound 2.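

In this assay, 3-bromopropoxy in place of nitro gives a 6.3-fold lower number from compound 2 to compound 3 (0.80 log units; beyond the scatter), so the higher number seen with nitro does not carry over to every group placed on this aromatic carbon. Exchanging fluoro for 3-bromopropoxy gives no change at the digits printed from compound 1 to compound 3 (within the scatter), which shows that this position can hold a chain of this length as well as a single fluoro without the number leaving the scatter. Nothing available explains why nitro stands apart from the other two groups.

From the compounds shown here alone, whether the bromine of 3-bromopropoxy contributes to the result remains open, and a plain propoxy group would be the direct comparison. It is also unknown whether a longer chain, an amine or a carboxylic acid on this carbon would stay close to fluoro and 3-bromopropoxy or move towards nitro.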